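The source may hold more compounds than are shown below. What is called first, only, known or untested is meant among the compounds shown, and "the series" means these compounds.

Working notes on the series. Compound 1 `N#C/C(=C\c1ccc[nH]1)C(=O)NCc1ccc(Cl)c(Cl)c1` and compound 2 `N#C/C(=C\c1ccccc1)C(=O)NCc1ccc(Cl)c(Cl)c1` share the same core and differ only in the group on the double-bonded chain carbon. In a functional assay on BE(2)-C cells (Homo sapiens) for inhibition, read by MTT assay, with a stated time of 72 h (a lower number here means a stronger inhibitor of growth, a higher number a weaker inhibitor of growth), compound 1 gives 43000 nM, and in this assay compound 2 gives 32000 nM. Going by the values given here, the step of a 1.3-fold lower number from compound 1 to compound 2 (0.13 log units; within the scatter) is the only measured step so far, and it lies within the scatter, so these two numbers do not separate the compounds. Compound 2 carries the lower of the two numbers, but with compound 1 within the scatter of it no order between them can be claimed.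

Compound 3 `N#C/C(=C\c1ccc(Cl)cc1)C(=O)NCc1ccc(Cl)c(Cl)c1` differs from compound 2 by chloro in place of hydrogen on an aromatic carbon, a chloro in place of hydrogen on an aromatic carbon of a six-membered aromatic ring of carbon only, para to a large group. Among the compounds with values here, no measured step bears directly on this change; the one step available concerns a different position and is itself within the scatter. The expected step of a 1.3-fold lower number from compound 2 to compound 3 (0.11 log units; within the scatter) is therefore small, not beyond the scatter. Compound 3 is estimated to give 25000 nM in this assay, within a range from 10000 nM to 60000 nM.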

Compound 3, concentration for 50% growth inhibition: 31000 nM
Estimate against measurement, compound 3: 1.2-fold (0.09 log units) below; measured number inside the range.
By their numbers in this assay, from the lowest: compounds 3, 2 and 1 (each within the scatter of the next).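

In this assay, going by these compounds alone, chloro in place of hydrogen on an aromatic carbon of the six-membered aromatic ring, para to a large group, gives the step of a 1.0-fold lower number from compound 2 to compound 3 (0.01 log units; within the scatter), so the first reading at this position does not separate the two compounds. Setting 4-chlorophenyl in place of 1H-pyrrol-2-yl gives the step of a 1.4-fold lower number from compound 1 to compound 3 (0.14 log units; within the scatter), which also lies within the scatter, so 1H-pyrrol-2-yl, phenyl and 4-chlorophenyl on the double-bonded chain carbon are not told apart by these numbers. No evidence at hand bears on this result.

Chloro is the only group shown at this position, so it stays open whether another group there, such as an amine or a carboxylic acid, would give a step beyond the scatter. All three compounds also share the rest of the core, which leaves open whether a longer chain between the amide nitrogen and its ring would give a number that separates from these three.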